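Spiro-fused cyclohexyl amide in place of the difluorocyclohexyl amide

The source may report more compounds than this note shows. Statements on the series, on what has been measured and on what is new or still open speak of the compounds shown alone.

Read-out is an assay on HEK293 cells for positive allosteric modulation of metabotropic glutamate receptor 5 (Homo sapiens), read by FLIPR; on this read-out lower numbers stand for an effect already at smaller amounts and higher numbers for an effect only at larger amounts of compound. Compound 1 `Cc1cccc(-c2noc(C3CN(S(=O)(=O)c4ccc(Cl)cc4)C3)n2)c1` gives > 10000 nM, which is a limit of the assay and not a number (the limit of > 10000 nM in this assay, at which 1 of the 2 values shown sits). Among the measured compounds shown here, compound 2 `O=C(C1CCC(F)(F)CC1)N1CC(c2nc(-c3cccc(Cl)c3)no2)C1` gives 180 nM, the only numerical value so far, so there is no measured step between two numbers against which to judge the size of the next change.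

Compound 3 `O=C(C1CCC2(CCC2)CC1)N1CC(c2nc(-c3cccc(Cl)c3)no2)C1` differs from compound 2 in one place (a group of 9 heavy atoms (9 carbon; one four-membered non-aromatic ring of carbon only, one six-membered non-aromatic ring of carbon only) in place of a group of 8 heavy atoms (6 carbon, 2 fluorine; one six-membered non-aromatic ring of carbon only), on a carbonyl carbon).

For the measured compounds named here, both groups are carbon-only aliphatic rings on the same carbonyl, without donors or acceptors, and the series gives no measured step for a change of this kind. The expectation is therefore a step from compound 2 to compound 3 that stays at or near the usual scatter, a 1.7-fold higher number from compound 2 to compound 3 (0.22 log units; within the scatter), with a modest loss considered somewhat more likely than a gain. For compound 3 the estimate is 300 nM, expected to fall in the range from 100 nM to 1200 nM.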

Compound 3, half-maximal effective concentration: 1100 nM
The estimate for compound 3 lay 3.7-fold (0.56 log units) below the measured number; the measured number falls inside the stated range.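

In this assay, among the compounds shown here, the place on the carbonyl carbon gives the first readable step: replacing 4,4-difluorocyclohexyl with the spiro-fused group gives a 6.1-fold higher number from compound 2 to compound 3 (0.79 log units; beyond the scatter). This place therefore responds to an exchange between two aliphatic carbocycles, even though neither group carries a hydrogen-bond donor or acceptor or a net charge. As the only step available, it gives a first measure of what a change here can do but establishes no trend, and no measurement shown bears on the reason for it.

The exchange removes the two fluorines and adds the four-membered ring in a single move, so the compounds shown leave open which of these changes accounts for the step; an unsubstituted cyclohexyl amide or a 4,4-dimethylcyclohexyl amide on the shared core would begin to separate them. Also open, going by these compounds, is how a morpholine amide, or a cyclohexyl ring carrying a carboxylic acid or an amine, would read in this assay, and whether the same step would recur with a different aryl group on the core.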